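Series notes: configuration change at the saturated ring carbon

This account rests on a few compounds, and the source may have more. Where it says the series, first, only, none or still open, it means among the compounds named here.

Compound 1, `O=C(NO)c1ccc(-c2cn([C@@H]3C[C@@H](C(=O)O)N(Cc4ccccc4)C3)nn2)cc1`: in an assay on Sf9 cells for inhibition of histone deacetylase 11 (Homo sapiens), read by fluorescence, tested at 0.5 uM (on this read-out higher numbers stand for more inhibition at the one concentration tested (going by the name of the read-out) and lower numbers for less inhibition), compound 1 gives < 10%, a limit of the assay.
Compound 2, `O=C(NO)c1cccc(-c2cn([C@@H]3C[C@@H](C(=O)O)N(CCCc4ccccc4)C3)nn2)c1`: in this assay compound 2 gives < 10%, a limit of the assay.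
Compound 3, `O=C(NO)c1cccc(-c2cn([C@@H]3C[C@H](C(=O)O)N(Cc4ccccc4)C3)nn2)c1`: in this assay compound 3 gives < 10%, a limit of the assay.

Compound 3 stands at the limit of < 10% in this assay, at which 3 of the 3 values shown sit. Among the measured compounds shown here, every value so far is a limit, and no step between measured compounds is set out, so no measured size of effect exists. Compound 4, `O=C(NO)c1cccc(-c2cn([C@@H]3C[C@@H](C(=O)O)N(Cc4ccccc4)C3)nn2)c1`, differs from compound 3 in configuration only: the two compounds have the same atoms and bonds and differ only in configuration as drawn: 1 of 2 stereo elements differ; a stereocentre at a saturated ring carbon is drawn R in compound 3 and S in compound 4. With only limits in hand, no step beyond the scatter is expected in this assay, in either direction. Compound 4 is therefore estimated at 5%, with a range from 0% to 15%, and a high chance that only a limit is again reported. The step that the limit leaves unreadable from compound 3 to compound 4 implied by this estimate is expected to be none beyond the scatter.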

Compound 4, a percentage reported as inhibition, at one concentration (the size of the read-out at that concentration, not a potency): < 10%
Compound 4: no number, only a limit; the forecaster's own chance of this, stated with the estimate: 80%; the middle value lies beyond the limit too.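

Compound 4 sits at the same limit as compounds 1, 2 and 3 in this assay, so no step to it can be read: the limit of < 10% in this assay, at which 4 of the 4 values shown sit.

Whether the configuration at the saturated ring carbon, or any other change shown, influences inhibition stays open.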